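This account rests on a few compounds, and the source may have more. Where it says the series, first, only, none or still open, it means among the compounds named here.

Series notes. The shared core is carried unchanged through compound 1 `Cn1c(-c2ccc(NC(=O)CSc3nc4ccccc4s3)cc2)nc(-c2ccccc2)c1-c1ccccc1`, compound 2 `Cn1cnnc1SCC(=O)Nc1ccc(-c2nc(-c3ccccc3)c(-c3ccccc3)n2C)cc1` and compound 3 `Cn1nnnc1SCC(=O)Nc1ccc(-c2nc(-c3ccccc3)c(-c3ccccc3)n2C)cc1`; only the ring attached to the sulfur is exchanged. In a functional assay on HT-29 cells (Homo sapiens) for cytotoxicity, read by MTT assay, with a stated time of 24 h, tested at 80 ug/mL (a lower number here means a weaker effect, a higher number a stronger effect of the compound at the concentration tested), compound 1 gives 82.7%, compound 2 gives 88% and compound 3 gives 89%. Compound 3 holds the highest of the three numbers, with compound 2 nearest and compound 1 furthest, yet both of those gaps lie within the scatter, so no order among the three can be read from them. The three steps, a number 5.3 percentage points higher from compound 1 to compound 2 (within the scatter), a number 6.3 percentage points higher from compound 1 to compound 3 (within the scatter) and a number 1 percentage points higher from compound 2 to compound 3 (within the scatter), all stay inside the scatter.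

The next compound, compound 4 `Cn1ccnc1SCC(=O)Nc1ccc(-c2nc(-c3ccccc3)c(-c3ccccc3)n2C)cc1`, differs from compound 3 in one place: 1-methyl-1H-imidazol-2-yl in place of 1-methyl-1H-tetrazol-5-yl on a sulfur. All three measured steps exchange one ring for another on a sulfur, and none of them moved this assay beyond the scatter. The exchange of the 1-methyl-1H-tetrazol-5-yl for the 1-methyl-1H-imidazol-2-yl is therefore expected to behave alike, with a step of a number 3 percentage points lower from compound 3 to compound 4 (within the scatter) that stays within the scatter. Compound 4 is expected to give 86%, within a range from 76% to 94%.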

Compound 4, a percentage reported as activity, at one concentration (the size of the read-out at that concentration, not a potency): 69.4%
For compound 4 the middle estimate is 16.6 percentage points above the measured one; the measured number lies below the stated range.
By their numbers in this assay, from the lowest: compound 4; then compounds 1, 2 and 3 (each within the scatter of the next).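

In this assay, among these compounds, the ring on the sulfur proves able to move the read-out: the 1-methyl-1H-imidazol-2-yl gives a number 19.6 percentage points lower from compound 3 to compound 4 (beyond the scatter) and a number 18.6 percentage points lower from compound 2 to compound 4 (beyond the scatter) and also a number 13.3 percentage points lower from compound 1 to compound 4 (beyond the scatter) and these are the first ring exchanges to leave the scatter, all towards a weaker effect at the concentration tested. The exchange of 1-methyl-1H-tetrazol-5-yl for 1-methyl-1H-imidazol-2-yl keeps the heavy-atom count and the five-membered aromatic ring, and replaces ring nitrogen with carbon, so a full change of ring size is not needed for a step of this kind. No measurement bearing on the reason for this drop is available.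

On these data alone, with only these four compounds, it remains open whether the lower number belongs to the 1-methyl-1H-imidazol-2-yl alone or extends to other rings with few hetero atoms, such as a 1-methyl-1H-pyrrol-2-yl. Also open, as far as these compounds go, is how an amine or a carboxylic acid on the ring at this sulfur, or a longer chain on the sulfur in place of the saturated chain carbon, would read in this assay.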